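Expected lipophilicity after a 2-ethoxyphenyl swap

The source may report more compounds than this note shows. Statements on the series, on what has been measured and on what is new or still open speak of the compounds shown alone.

In a physicochemical assay for lipophilicity, read by HPLC, at pH 7.5 (on this read-out lower numbers stand for lower lipophilicity and higher numbers for higher lipophilicity), compound 3 `CC[C@@H](Nc1c(C#N)c(-c2ccc(-c3cccc(CO)c3)cc2)nc2cnccc12)C(N)=O` gives 2, level with compound 1 `CC[C@@H](Nc1c(C#N)c(-c2ccc(-c3ccncc3C)cc2)nc2cnccc12)C(N)=O` at 2, while compound 2 `CC[C@@H](Nc1c(C#N)c(-c2ccc(-c3cccc(Cl)c3OC)cc2)nc2cnccc12)C(N)=O` gives 3.1. Compound 4 `CCOc1ccccc1-c1ccc(-c2nc3cnccc3c(N[C@H](CC)C(N)=O)c2C#N)cc1` carries 2-ethoxyphenyl in place of 3-(hydroxymethyl)phenyl on an aromatic carbon, para to a large group (2-ethoxyphenyl in place of 3-(hydroxymethyl)phenyl on an aromatic carbon). Within the data shown here, two measured steps bear on this change. The closer guide is a number 1.10 log units lower from compound 2 to compound 3 (beyond the scatter), where 3-(hydroxymethyl)phenyl replaces 3-chloro-2-methoxyphenyl, and the other is no change at the digits printed from compound 1 to compound 3 (within the scatter), where it replaces 3-methylpyridin-4-yl. Among the measured compounds shown here, no measured compound carries 2-ethoxyphenyl itself. A large rise is therefore expected, slightly smaller than the first of these steps, and the expected step is a number 0.90 log units higher from compound 3 to compound 4 (beyond the scatter). For compound 4, the estimated value is 2.9, with an expected range from 2.5 to 3.3.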

Compound 4, distribution coefficient: 3
For compound 4 the middle estimate is 0.10 log units below the measured one, and the stated range covers the measured number.
By their numbers in this assay, from the lowest: compounds 1 and 3 (each within the scatter of the next); then compounds 4 and 2 (each within the scatter of the next).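

In this assay, 2-ethoxyphenyl on this aromatic carbon sits with 3-chloro-2-methoxyphenyl, showing a number 0.10 log units lower from compound 2 to compound 4 (within the scatter), and clear of the other two groups, showing a number 1.00 log units higher from compound 3 to compound 4 (beyond the scatter) and a number 1.00 log units higher from compound 1 to compound 4 (beyond the scatter). The high level seen so far only with compound 2 is thus reached by a second group, one that has no chlorine. Nothing available gives a reason for this result. The compounds shown leave open how a longer chain, as in 2-propoxyphenyl, or an amine, as in 2-(dimethylamino)phenyl, would read at this carbon.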